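Halogen swap on the shared core: chloro to bromo

The source may report more compounds than this note shows. Statements on the series, on what has been measured and on what is new or still open speak of the compounds shown alone.

Among the compounds with values here, compound 2 `CN1CCC(NC(=O)c2ccc(Nc3ncc(Cl)c(NC4CCCC4)n3)cc2)CC1` gives 1800 nM in a functional assay on A549 cells (Homo sapiens) for cytotoxicity, read by MTT assay, with a stated time of 48 h (on this read-out higher numbers stand for weaker inhibition and lower numbers for stronger inhibition), and stands as the lower of the two numbers so far, compound 1 `CN1CCC(NC(=O)c2ccc(Nc3ncc([N+](=O)[O-])c(NC4CCCC4)n3)cc2)CC1` giving 42300 nM in this assay. Within the data shown here, the only measured step, a 24-fold lower number from compound 1 to compound 2 (1.37 log units; beyond the scatter), joins these two compounds and is large. Compound 3 `CN1CCC(NC(=O)c2ccc(Nc3ncc(Br)c(NC4CCCC4)n3)cc2)CC1` is not yet measured; against compound 2 the difference is bromo in place of chloro on an aromatic carbon. Among the measured compounds shown here, no measured step concerns an exchange of one halogen for another at this carbon; the nitro-to-chloro step shows how far the number can move at that position, but it says nothing about chloro against bromo, so the two measured values alone carry the expectation. For compound 3 the expected step is a 1.2-fold lower number from compound 2 to compound 3 (0.08 log units; within the scatter), which is not beyond the scatter. Compound 3 is estimated at 1500 nM, with a range from 600 nM to 4000 nM.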

Compound 3, half-maximal inhibitory concentration: 500 nM
Compound 3: the middle estimate sits 3.0-fold (0.48 log units) above what was measured; measured number below the stated range.
By their numbers in this assay, from the lowest: compound 3; then compound 2; then compound 1.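

In this assay the two halogens at this aromatic carbon are not interchangeable: the change gives a 3.6-fold lower number from compound 2 to compound 3 (0.56 log units; beyond the scatter) and so moves the number although the counted ring, hydrogen-bond donors, hydrogen-bond acceptors and net charge stay the same. The span at this carbon also widens beyond what the nitro-to-chloro step showed, with an 85-fold lower number from compound 1 to compound 3 (1.93 log units; beyond the scatter) as the largest step in the series, and the three groups now order as bromo, chloro, nitro from the lowest number. No measured evidence bears on the origin of the difference between bromo and chloro.

From the compounds shown here alone, whether the order continues to iodo or extends back to fluoro stays open, as does the place of a methyl or nitrile group at this carbon. Going by these compounds, with the cyclopentylamino group held constant throughout, it also remains open whether the bromo-over-chloro step survives a change to a smaller amine there.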